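A few compounds are considered here, and "the series" means these few. Any claim that something is new, unique, unknown or untested is made for them only; others in the source may bear on it.

Three compounds share one core, each carrying the same amide-linked side chain. In a functional assay on PC-12 cells (Rattus norvegicus) for cytotoxicity, read by MTT assay, with stated times of 3 h and 2 h, tested at 0.1 uM (on this read-out lower numbers stand for a weaker effect and higher numbers for a stronger effect at the one concentration tested), compound 1 `O=C(CCCCC1CCSS1)NCc1cn(CCCCOc2ccc3cc(-c4ccccc4)c(=O)oc3c2)nn1` gives 38.6%, compound 2 `Cc1cc(=O)oc2cc(OCCCCCn3cc(CNC(=O)CCCCC4CCSS4)nn3)ccc12` gives 45.6%, and compound 3 `CC(=O)c1cc2ccc(OCCCCCn3cc(CNC(=O)CCCCC4CCSS4)nn3)cc2oc1=O` gives 28.9%. Compound 3 shows the lowest of the three numbers: it sits below compound 2 by more than the usual scatter, while compound 3 and compound 1 lie within the scatter of each other. Compound 4 `O=C(CCCCC1CCSS1)NCc1cn(CCCCCOc2ccc3cc(-c4ccccc4)c(=O)oc3c2)nn1` differs from compound 3 in one place: phenyl in place of acetyl on an aromatic carbon. For the measured compounds named here, no measured pair differs in just one place, so the size of this step is uncertain. The step of a number 7.1 percentage points higher from compound 3 to compound 4 (within the scatter) is expected to be small, within the scatter, since compound 1 gives 38.6% while also carrying the phenyl. Compound 4 is estimated at 36%, ranging from 24% to 48%.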

Compound 4, a percentage reported as activity, at one concentration (the size of the read-out at that concentration, not a potency): 35.5%
The estimate for compound 4 lay 0.5 percentage points above the measured number; the range from low to high includes it.
By their numbers in this assay, from the lowest: compounds 3, 4, 1 and 2 (each within the scatter of the next, the first and the last beyond it).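

For the compounds shown here, replacing acetyl with phenyl on this aromatic carbon, two atoms from the ring oxygen, gives the first one-place comparison in this assay, with a number 6.6 percentage points higher from compound 3 to compound 4 (within the scatter). A six-membered aromatic ring of carbon only can therefore take the place of acetyl, with its hydrogen-bond acceptor, without the read-out at this one concentration leaving the scatter. Nothing available here gives a reason for this outcome. As far as these compounds go, whether an amine or a carboxylic acid at this position would give a step beyond the scatter stays open, as does the effect of this exchange at other concentrations.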